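Acyl group exchange on the ring amine nitrogen

A few compounds are considered here, and "the series" means these few. Any claim that something is new, unique, unknown or untested is made for them only; others in the source may bear on it.

Among the compounds with values here, compound 2 `CC(C)SC(=O)N1CCC(Oc2ncnc3c2CCN3c2ccc(S(C)(=O)=O)cc2F)CC1` gives 138% in a functional assay on CHO-K1 cells with Glucose-dependent insulinotropic receptor (Homo sapiens) as the target, read by a luciferase reporter, with a stated time of 5 h (a higher number here means a larger maximal response, a lower number a smaller maximal response), the higher of the two numbers so far; compound 1 `CCCOC(=O)N1CCC(Oc2ncnc3c2CCN3c2ccc(S(C)(=O)=O)cc2F)CC1` gives 111%, and the step of a number 27 percentage points higher from compound 1 to compound 2 (beyond the scatter) lies beyond the scatter. Compound 3 `CS(=O)(=O)c1ccc(N2CCc3c(OC4CCN(C(=S)Sc5ccccc5)CC4)ncnc32)c(F)c1` carries a group of 9 heavy atoms (7 carbon, 2 sulfur; one six-membered aromatic ring of carbon only) in place of a group of 6 heavy atoms (4 carbon, 1 oxygen, 1 sulfur; no ring), on an amine nitrogen in a ring. Within the data shown here, no measured step covers this exchange; the only known step, a number 27 percentage points higher from compound 1 to compound 2 (beyond the scatter), concerned a different pair of groups on the same nitrogen and is at best a loose guide. The step is therefore expected to stay within the scatter, a number 13 percentage points lower from compound 2 to compound 3 (beyond the scatter), with wide uncertainty. Compound 3 is estimated at 125%, range 85% to 165%.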

Compound 3, largest response reached (reported as percent of maximum), in percent of the reference or control that the assay uses: 103%
The estimate for compound 3 lay 22 percentage points above the measured number; low and high end bracket the measured number.
By their numbers in this assay, from the lowest: compounds 3 and 1 (each within the scatter of the next); then compound 2.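

In this assay the group of 9 heavy atoms with its six-membered aromatic ring, placed on the amine nitrogen in a ring, gives a number 35 percentage points lower from compound 2 to compound 3 (beyond the scatter) and so does not keep the raised maximal response of compound 2. Against the propoxy carbonyl group it gives a number 8 percentage points lower from compound 1 to compound 3 (within the scatter) and the two compounds stay level. Nothing measured on these compounds explains the drop.

Open, going by these compounds, is whether the sulfur atoms or the aromatic ring account for it. A phenoxycarbonyl or isopropoxycarbonyl group on this nitrogen would separate the two.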